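A few compounds are considered here, and "the series" means these few. Any claim that something is new, unique, unknown or untested is made for them only; others in the source may bear on it.

Measured in a functional assay on HT-29 cells (Homo sapiens) for cytotoxicity, read by sulforhodamine B assay; a lower number here means that less compound is tolerated, a higher number that more compound is tolerated:
- Compound 1 `CC1=CC[C@@H]([C@@](C)(O)CCCC(C)(C)NC(=S)N/N=C\c2ccc(O)cc2)CC1`: 58500 nM
- Compound 2 `CC1=CC[C@@H]([C@@](C)(O)CCCC(C)(C)NC(=S)N/N=C\c2cccc([N+](=O)[O-])c2)CC1`: > 100000 nM

Compound 2 reads > 100000 nM, and this is a limit of the assay, not a number. For compound 2 the position is therefore only a bound: the limit of > 100000 nM in this assay, at which 1 of the 2 values shown sits.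

Compound 3 `CC1=CC[C@@H]([C@@](C)(O)CCCC(C)(C)NC(=S)N/N=C\c2ccc([N+](=O)[O-])cc2)CC1` has the same atoms as compound 2, joined differently: 4-nitrophenyl in place of 3-nitrophenyl on a carbon with a double bond to nitrogen. In words, it carries 4-nitrophenyl in place of 3-nitrophenyl on a carbon with a double bond to nitrogen.

Within the data shown here, only one measured step bears on this change, at the same place: an at least 1.7-fold higher number from compound 1 to compound 2 (0.23 log units; that floor lies within the scatter). Among the measured compounds shown here, no measured pair compares the two nitrophenyl groups directly. For the measured compounds named here, the only true number is that of compound 1 at 58500 nM, so the expectation is for no step beyond the scatter in this assay. Compound 2 starts from > 100000 nM, which is a limit, so any movement is more likely toward a lower number. The expected change is an at least 1.2-fold lower number from compound 2 to compound 3 (0.09 log units; that floor lies within the scatter). Compound 3 is estimated at 80000 nM, with an expected range from 35000 nM to 150000 nM.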

Compound 3, concentration lethal to 50% of the cells: > 100000 nM
Compound 3 was reported as a limit (the forecaster's own chance of this, stated with the estimate: 40%); middle value at least 1.2-fold (0.09 log units) from the limit.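

In this assay compound 3 gives > 100000 nM, which is a limit of the assay and not a number. The step between the two nitrophenyl compounds cannot be read, so moving from 3-nitrophenyl to 4-nitrophenyl on a carbon with a double bond to nitrogen shows only that both compounds now sit at the same limit: the limit of > 100000 nM in this assay, at which 2 of the 3 values shown sit.

Nitro in place of hydroxy on an aromatic carbon gives an at least 1.7-fold higher number from compound 1 to compound 3 (0.23 log units; that floor lies within the scatter), the same floor as the 3-nitrophenyl group gave in an at least 1.7-fold higher number from compound 1 to compound 2 (0.23 log units; that floor lies within the scatter), so a second nitrophenyl group adds no step that can be read beyond the scatter.

Going by these compounds, whether either nitrophenyl compound truly differs from compound 1 stays open, and so does any order between compound 2 and compound 3. An amine or a carboxylic acid in place of the nitro group on the same aromatic ring could show whether anything at this position moves the number clearly away from that of compound 1.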